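Amide Substituent Exchange on a Shared Core

The source may hold more compounds than are shown below. What is called first, only, known or untested is meant among the compounds shown, and "the series" means these compounds.

Measured compounds:
compound 1, `COc1ccc2c(=O)c(/C=C/C(=O)NCc3ccc(F)cc3)coc2c1`, 21000 nM
compound 2, `COc1ccc(CNC(=O)/C=C/c2coc3cc(OC)ccc3c2=O)cc1`, 7570 nM

In a functional assay on Huh-7 cells (Homo sapiens) for inhibition, read by MTT assay, with a stated time of 48 h (a higher number here means a weaker inhibitor, a lower number a stronger inhibitor), compound 1 gives 21000 nM, while compound 2 gives 7570 nM. Going by the values given here, the only step between the two, a 2.8-fold lower number from compound 1 to compound 2 (0.44 log units; beyond the scatter), is a methoxy in place of fluoro on an aromatic carbon. Among the compounds with values here, compound 2 therefore stands lowest of the two numbers, with compound 1 as its sole neighbour.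

Compound 3, `CCOc1ccc(NC(=O)/C=C/c2coc3cc(OC)ccc3c2=O)cc1`, differs from compound 2 by 4-ethoxyphenyl in place of 4-methoxybenzyl on an amide-type nitrogen. Within the data shown here, the single measured step bears only loosely on this change: it swaps one substituent on the aromatic ring while the attachment of that ring to the amide-type nitrogen is unchanged, whereas here the attachment itself is rebuilt from the same atoms. Among the measured compounds shown here, no measured pair follows such a rearrangement, so the data give no direction for it.

The expectation is therefore a step of no more than the scatter, a 1.1-fold higher number from compound 2 to compound 3 (0.02 log units; within the scatter), held with a wide range. Compound 3 is thus estimated at 8000 nM, expected to fall between 2500 nM and 25000 nM.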

Compound 3, half-maximal inhibitory concentration: 3230 nM
For compound 3 the middle estimate is 2.5-fold (0.39 log units) above the measured one, within the range that was stated.
By their numbers in this assay, from the lowest: compound 3; then compound 2; then compound 1.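

In this assay, the amide-type nitrogen proves sensitive to how its substituent is assembled, not only to what the ring carries: a 2.3-fold lower number from compound 2 to compound 3 (0.37 log units; beyond the scatter) comes from the same atoms joined differently, and that step lies beyond the scatter. Set against the 4-fluorobenzyl group, the 4-ethoxyphenyl group gives a 6.5-fold lower number from compound 1 to compound 3 (0.81 log units; beyond the scatter) and so changes the ring's substituent and its attachment in one exchange, whereas the earlier step changed only the substituent on a benzyl ring. Nothing given here accounts for either step, and no independent measurement bears on them.

The exchange between compound 2 and compound 3 joins two changes, the ring now attached directly to the amide-type nitrogen and ethoxy standing where methoxy stood, so the compounds shown cannot assign the step to either change; a 4-methoxyphenyl or a 4-ethoxybenzyl group would separate them. From the compounds shown here alone, it also remains open how the directly attached ring responds to other substituents, such as an amine, a carboxylic acid or a longer alkoxy chain in place of the ethoxy group.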